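The compounds below may be only part of what the source reports. "The series", "measured", "known", "first", "only" and "open" are said of these compounds alone.

Measured compounds in an assay on isolated protein for inhibition of DNA topoisomerase 1 (Homo sapiens), with a stated time of 30 min, tested at 100 uM; on this read-out lower numbers stand for a weaker effect and higher numbers for a stronger effect at the one concentration tested:
compound 1, `Oc1cccc(-c2cc(-c3cccs3)cc(-c3ccccc3O)n2)c1`, 83.2%;
compound 2, `Oc1cccc(-c2cc(-c3cccs3)cc(-c3cccc(O)c3)n2)c1`, 91.7%;
compound 3, `Oc1ccc(-c2cc(-c3cccs3)cc(-c3cccc(O)c3)n2)cc1`, 85.7%.

Compound 2 gives the highest of the three numbers, yet its steps to the others, a number 6 percentage points lower from compound 2 to compound 3 (within the scatter) and, read from compound 1, a number 8.5 percentage points higher from compound 1 to compound 2 (within the scatter), both lie within the scatter, so the three values cannot be told apart. Every measured step, including a number 2.5 percentage points higher from compound 1 to compound 3 (within the scatter), exchanges one hydroxyphenyl group for another; none touches the thiophen-2-yl. Compound 4, `Oc1cccc(-c2cc(-c3ccccn3)cc(-c3cccc(O)c3)n2)c1`, differs from compound 2 by pyridin-2-yl in place of thiophen-2-yl on an aromatic carbon. Among the measured compounds shown here, no measured step bears on this change, so the series gives no direction for it. The expected step is a number 6.7 percentage points lower from compound 2 to compound 4 (within the scatter), none beyond the scatter, with a wide range. Compound 4 is estimated at 85%, between 60% and 97%.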

Compound 4, a percentage reported as inhibition, at one concentration (the size of the read-out at that concentration, not a potency): 8.3%
Estimate against measurement, compound 4: 76.7 percentage points above; measured number below the stated range.
By their numbers in this assay, from the lowest: compound 4; then compounds 1, 3 and 2 (each within the scatter of the next).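

In this assay the position opposite the ring nitrogen proves far more sensitive than the hydroxyphenyl groups: pyridin-2-yl in place of thiophen-2-yl gives a number 83.4 percentage points lower from compound 2 to compound 4 (beyond the scatter) while every hydroxyphenyl exchange stayed within the scatter. Swapping one aromatic ring with a single hetero atom for another is thus enough to remove nearly all of the effect at this position. No available evidence bears on the origin of this loss.

On these data alone, whether the loss is specific to pyridin-2-yl or extends to other replacements of thiophen-2-yl remains open; phenyl, furan-2-yl or pyridin-3-yl at this position would help separate these cases. Also open, as far as these compounds go, is whether the same change has a similar effect alongside 2-hydroxyphenyl or 4-hydroxyphenyl groups.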